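The compounds below may be only part of what the source reports. "The series", "measured", "known", "first", "only" and "open" are said of these compounds alone.

In a functional assay on CCRF-CEM cells (Homo sapiens) for inhibition (a lower number here means a stronger inhibitor, a higher number a weaker inhibitor), compound 1 `O=C1/C(=C/c2ccccc2F)CCc2ccccc21` gives 20800 nM and compound 2 `O=C1/C(=C/c2ccccc2Br)CCCc2ccccc21` gives 32100 nM. Within the data shown here, these two numbers lie within the usual scatter of repeated measurements, so compound 1 cannot be told apart from compound 2, the only other compound measured so far. Compound 3 `O=C1/C(=C/c2ccccc2Br)CCc2ccccc21` keeps the core of compound 1 and alters it in a single place: bromo in place of fluoro on an aromatic carbon, ortho to a large group (bromo in place of fluoro on an aromatic carbon). Among the measured compounds shown here, no measured pair shows what a single change does here, so the size of this step has no direct precedent. With so little to go on, the expectation is no shift beyond the scatter, and the estimated step is small: a 1.1-fold higher number from compound 1 to compound 3 (0.02 log units; within the scatter). For compound 3 the expected value is 22000 nM, with an estimated range of 10000 nM to 45000 nM.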

Compound 3, half-maximal inhibitory concentration: 25400 nM
Compound 3: the middle estimate sits 1.2-fold (0.06 log units) below what was measured, within the range that was stated.
By their numbers in this assay, from the lowest: compounds 1, 3 and 2 (each within the scatter of the next).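

Among these compounds, putting bromo in place of fluoro on this aromatic carbon, ortho to a large group, gives the first single-place step in this assay, and that step is a 1.2-fold higher number from compound 1 to compound 3 (0.09 log units; within the scatter). On the core of compound 1, then, this exchange of one group for another leaves the reading indistinguishable from the starting point, so fluoro and bromo cannot be told apart at this position. No supporting measurement is available to explain this result.

As far as these compounds go, it remains open whether a quite different group at the same carbon, such as an amine, a methoxy group or a carboxylic acid, would move the number beyond the scatter. From the compounds shown here alone, it is also open whether bromo in place of fluoro would give a similarly small step at another carbon of this ring.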